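This account rests on a few compounds, and the source may have more. Where it says the series, first, only, none or still open, it means among the compounds named here.

Measured so far:
compound 1 `CC(C)(C)c1cc(N)c2cc(NC(=O)/C=C/c3ccc(C(F)(F)F)cc3)ccc2n1`, 0.3 nM
compound 2 `CCCc1cc(N)c2cc(NC(=O)/C=C/c3ccc(F)cc3)ccc2n1`, 130 nM

Both numbers come from an assay on isolated protein for displacement of a labelled ligand from melanin-concentrating hormone receptor 1 (Homo sapiens); a lower number here means a stronger inhibitor, a higher number a weaker inhibitor. Compound 1 gives the lower of the two, and compound 2, which differs from compound 1 in more than one place, sits at a far higher number, a gap well beyond the scatter. For the measured compounds named here, no comparison between compounds that differ in a single place is available among the measured pair.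

Compound 3 `Nc1cc(C2CCC2)nc2ccc(NC(=O)/C=C/c3ccc(C(F)(F)F)cc3)cc12` is the next compound. Relative to compound 1 the change is cyclobutyl in place of tert-butyl on an aromatic carbon. Nothing measured here isolates what this swap does, so the expectation rests on compound 1 and its value alone. The step is expected to be small, with no direction beyond the scatter assumed. The estimate for compound 3 in this assay is 0.8 nM, with a range of 0.2 nM to 4 nM. This estimate implies an expected step of a 2.7-fold higher number from compound 1 to compound 3 (0.43 log units; beyond the scatter).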

Compound 3, half-maximal inhibitory concentration: 2 nM
Compound 3: the middle estimate sits 2.5-fold (0.40 log units) below what was measured; low and high end bracket the measured number.
By their numbers in this assay, from the lowest: compound 1; then compound 3; then compound 2.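

For the compounds shown here, this is the first single-place comparison: in this assay, cyclobutyl in place of tert-butyl on the aromatic carbon next to the ring nitrogen gives a 6.7-fold higher number from compound 1 to compound 3 (0.82 log units; beyond the scatter), a modest step beyond the scatter. The position therefore distinguishes between these two four-carbon groups, even though heavy-atom, donor and acceptor counts stay the same, and compound 3 at 2 nM still keeps the number in the low nanomolar range. Nothing shown here explains the step.

Going by these compounds, what isopropyl, cyclopropyl or a ring carrying an amine would give on this aromatic carbon remains open. Also open, on these data alone, is whether the step carries over when fluoro stands in place of trifluoromethyl, and how much of the gap to compound 2 belongs to its propyl chain rather than its fluoro group.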